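Extending the ethyl group of compound 3

The source may hold more compounds than are shown below. What is called first, only, known or untested is meant among the compounds shown, and "the series" means these compounds.

In a physicochemical assay for solubility, read by HPLC, at pH 2 (a higher number here means a more soluble compound, a lower number a less soluble compound), compound 1 `OC1CC2(CCN(CCC3CCCCC3)CC2)Oc2c1ccc1ccccc21` gives 40000 nM and compound 2 `c1ccc2c3c(ccc2c1)CCC1(CCNCC1)O3` gives 40000 nM. Compound 3 `CCN1CCC2(CCc3ccc4ccccc4c3O2)CC1` reads <= 10000 nM, which is a limit and not a number. Compound 4 `c1ccc2c3c(ccc2c1)CCC1(CCN(CCC2CCCCC2)CC1)O3` differs from compound 3 by one change (cyclohexyl in place of hydrogen on a saturated chain carbon, two bonds along the chain from an amine nitrogen in a ring), which turns ethyl into 2-cyclohexylethyl. Within the data shown here, one measured step bears on this change: an at least 4.0-fold lower number from compound 2 to compound 3 (0.60 log units; beyond the scatter), with ethyl in place of hydrogen on an amine nitrogen in a ring. That single step is at least modest and lies beyond the scatter. No further move beyond the scatter is expected in this assay, and the expected step is a number no lower from compound 3 to compound 4 (the limit leaves the size open). The estimate for compound 4 is 10000 nM, with an expected range from 4000 nM to 35000 nM.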

Compound 4, solubility: 40000 nM
For compound 4 the middle estimate is 4.0-fold (0.60 log units) below the measured one; the measured number lies above the stated range.
By their numbers in this assay, from the lowest: compounds 1, 2 and 4 (each within the scatter of the next). At a limit, below all of these: compound 3.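

In this assay, cyclohexyl on this saturated chain carbon gives an at least 4.0-fold higher number from compound 3 to compound 4 (0.60 log units; beyond the scatter), so the lower number seen with ethyl does not hold for every group on this amine nitrogen. The 2-cyclohexylethyl group in place of hydrogen gives no change at the digits printed from compound 2 to compound 4 (within the scatter), and hydrogen in place of hydroxy on a saturated ring carbon gives no change at the digits printed from compound 1 to compound 4 (within the scatter). The true size of the gain from ethyl stays open, since compound 3 stands at a limit: the limit of <= 10000 nM in this assay, at which 1 of the 4 values shown sits.

As far as these compounds go, whether a propyl chain, a phenyl group or a terminal carboxylic acid at this position would read like ethyl or like 2-cyclohexylethyl remains open.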